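The source may hold more compounds than are shown below. What is called first, only, known or untested is meant among the compounds shown, and "the series" means these compounds.

Measured so far:
Compound 1 `CC(C)(C)OC(=O)NCCCCCN1C(Nc2ccc(-c3ccccc3)cc2)=Nc2ccccc2C1CC(=O)NCc1ccccc1`: 2010 nM
Compound 2 `O=C(CC1c2ccccc2N=C(N2CCCCC2)N1c1ccccc1)NCc1ccc(NS(=O)(=O)c2ccc(F)cc2)cc1`: 1950 nM

In a functional assay on SK-OV-3 cells (Homo sapiens) for inhibition, read by sulforhodamine B assay, with a stated time of 72 h (a lower number here means a stronger inhibitor of growth, a higher number a weaker inhibitor of growth), compound 2 gives 1950 nM and compound 1 gives 2010 nM, two numbers that lie within the scatter of each other, so neither can be placed ahead of the other. Compound 3 `CCN1C(N2CCCCC2)=Nc2ccccc2C1CC(=O)NCc1ccc(NS(=O)(=O)c2ccc(F)cc2)cc1` differs from compound 2 by ethyl in place of phenyl on an amine nitrogen in a ring. Going by the values given here, no measured pair shows this change, so its size is unknown from the data. The change is expected to weaken inhibition somewhat, a step estimated at a 2.1-fold higher number from compound 2 to compound 3 (0.31 log units; beyond the scatter). Compound 3 is expected to give about 4000 nM, within a range from 1500 nM to 12000 nM.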

Compound 3, concentration for 50% growth inhibition: 26100 nM
Beside the measured number, compound 3's estimate is 6.5-fold (0.81 log units) below it, and the stated range ends below it.
By their numbers in this assay, from the lowest: compounds 2 and 1 (each within the scatter of the next); then compound 3.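

In this assay, the group on this amine nitrogen in a ring proves to matter greatly: ethyl in place of phenyl gives a 13-fold higher number from compound 2 to compound 3 (1.13 log units; beyond the scatter) and so marks this position as the first shown here to be sensitive to change. With the piperidin-1-yl group and the rest of the molecule held constant, the loss follows this single change. Nothing available explains the size of this step.

Going by these compounds, whether a cyclohexyl group, a benzyl group or a longer alkyl chain on this nitrogen would restore the number of compound 2 stays open. So does whether substituted phenyl groups would improve on it.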